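Trading benzoyl for propyl on compound 1

This account rests on a few compounds, and the source may have more. Where it says the series, first, only, none or still open, it means among the compounds named here.

- Compound 1 `O=C(Oc1ccc2ccc(=O)oc2c1CN1CCc2ccccc2C1)c1ccccc1` gives > 100000 nM as a limit
- Compound 2 `COc1ccc2[nH]cc(Cc3c(OC(C)=O)ccc4c(C)cc(=O)oc34)c2c1` gives 72000 nM as a number

In an ADME assay on MT4 cells (Homo sapiens) for cytotoxicity, read by MTT assay, with a stated time of 96 h (a higher number here means that more compound is tolerated, a lower number that less compound is tolerated), compound 1 gives > 100000 nM and this is a limit of the assay, not a number. Compound 1 therefore stands at the limit of > 100000 nM in this assay, at which 1 of the 2 values shown sits, and has no exact value. Compound 2 gives 72000 nM as a true number, but no single change links it to compound 1.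

The next compound to be tested is compound 3 `CCCOc1ccc2ccc(=O)oc2c1CN1CCc2ccccc2C1` with propyl in place of benzoyl on an oxygen on an aromatic ring. The rest of compound 1 stays as it is. For the measured compounds named here, no measured step shows what this swap does, so the expectation in this assay is loose: a modest move towards less compound tolerated, or a result that again stops at the limit. It leans on compound 2, whose 72000 nM shows that a number can be read in this group of compounds. The expected change is an at least 1.5-fold lower number from compound 1 to compound 3 (0.18 log units; that floor lies within the scatter) and it remains an estimate. For compound 3 the expected value is 65000 nM with an estimated range from 20000 nM to 100000 nM before any measurement is known.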

Compound 3, half-maximal cytotoxic concentration: 11000 nM
Estimate against measurement, compound 3: 5.9-fold (0.77 log units) above, and the stated range ends above it.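

For the compounds shown here, changing benzoyl to propyl on the oxygen on the aromatic ring, with the rest of the core of compound 1 kept, gives the first comparison in which only one place differs in this assay: the change gives an at least 9.0-fold lower number from compound 1 to compound 3 (0.95 log units; beyond the scatter). This shows that the group on this oxygen can by itself shift how much compound the cells tolerate, and that propoxy lies on the less tolerated side of benzoyloxy. The size of the step is only a floor, because the value for compound 1 is a limit and not a number: the limit of > 100000 nM in this assay, at which 1 of the 3 values shown sits.

A single pair cannot tell which part of the swap matters, as the aromatic ring, the carbonyl and the length of the group all change together. From the compounds shown here alone, a benzyl group on the same oxygen would keep the ring without the carbonyl, while a longer chain such as hexyl would test length alone, so the roles of these features remain open.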